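A few compounds are considered here, and "the series" means these few. Any claim that something is new, unique, unknown or untested is made for them only; others in the source may bear on it.

Measured so far:
compound 1 `NC1=NC2(CCOCC2)N(OCCCOc2ccc(F)cc2)C(N)=N1` — 3280 nM
compound 2 `COc1ccc(OCCCON2C(N)=NC(N)=NC23CCSCC3)cc1` — 70 nM

Within the data shown here, in a functional assay on HCT-116 cells (Homo sapiens) for antiproliferative activity, read by MTT assay, with a stated time of 72 h (a higher number here means a weaker inhibitor, a lower number a stronger inhibitor), compound 1 gives 3280 nM, the highest of the two numbers, and compound 2 gives 70 nM, a gap that lies beyond the scatter; the two differ in more than one place, so their values alone show no single step. Compound 3 `Cc1cc(C)cc(OCCCON2C(N)=NC(N)=NC23CCOCC3)c1` differs from compound 1 by 3,5-dimethylphenyl in place of 4-fluorophenyl on an oxygen on a saturated carbon. Among the measured compounds shown here, no step for this change has been measured, so the expected size of a 2.2-fold lower number from compound 1 to compound 3 (0.34 log units; beyond the scatter) rests on judgement alone; a modest drop in the number, of moderate size, is expected. Compound 3 is therefore expected to give 1500 nM, within 300 nM to 6000 nM.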

Compound 3, half-maximal inhibitory concentration: 190 nM
The estimate for compound 3 lay 7.9-fold (0.90 log units) above the measured number, and the stated range ends above it.
By their numbers in this assay, from the lowest: compound 2; then compound 3; then compound 1.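

In this assay, among these compounds, the group on an oxygen on a saturated carbon has a large effect on the number: 3,5-dimethylphenyl in place of 4-fluorophenyl gives a 17-fold lower number from compound 1 to compound 3 (1.24 log units; beyond the scatter), the first single change that can be read here. The two groups are both carbon-only aromatic rings with no hydrogen-bond donors or acceptors and no net charge, yet the step lies beyond the scatter. Nothing measured here bears on why the number falls.

Going by these compounds, the change removes the fluorine and adds both methyl groups at once, so it remains open which of these matters. On these data alone, how a plain phenyl, or a phenyl bearing an amine, would compare also remains open.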